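Amide tail variation: furan-2-yl to cyclobutyl

A few compounds are considered here, and "the series" means these few. Any claim that something is new, unique, unknown or untested is made for them only; others in the source may bear on it.

The shared core is that of compound 1 `COc1ccccc1C(=O)Nc1cccc(NC(=O)c2cc(Cl)cc(Cl)c2)c1`, which in an in vitro functional assay on HEK293-A cells for antagonist activity at metabotropic glutamate receptor 5 (Rattus norvegicus), read by calcium flux (a lower number here means a stronger inhibitor, a higher number a weaker inhibitor), returns only the limit > 30000 nM, a limit of the assay and not a number. Compound 2 `COc1ccccc1C(=O)Nc1cccc(NC(=O)c2cccc(F)c2)c1` gives 6480 nM in this assay. Compound 3 `COc1ccccc1C(=O)Nc1cccc(NC(=O)c2ccco2)c1` returns in this assay the limit > 30000 nM, again a limit rather than a number. Compound 3 therefore stands at the limit, sharing it with compound 1 (the limit of > 30000 nM in this assay, at which 2 of the 3 values shown sit), while compound 2 alone yields a number; the step of an at least 4.6-fold lower number from compound 1 to compound 2 (0.66 log units; beyond the scatter) and the step of an at least 4.6-fold higher number from compound 2 to compound 3 (0.66 log units; beyond the scatter) are readable only as limits, and the step that the two limits leave unreadable from compound 1 to compound 3 is not readable at all.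

Compound 4 `COc1ccccc1C(=O)Nc1cccc(NC(=O)C2CCC2)c1` differs from compound 3 in one place: cyclobutyl in place of furan-2-yl on a carbonyl carbon. Among the measured compounds shown here, none of the measured steps bears directly on this exchange, since each of them replaces one aromatic tail with another aromatic tail; no saturated ring has been measured. What the numbers do show is that two of three tails on this carbonyl carbon give only the limit, and compound 3 starts there. The step of a number no higher from compound 3 to compound 4 (the limit leaves the size open) is expected to be small, with the limit the most likely outcome. Compound 4 is estimated at 30000 nM, within 8000 nM to 100000 nM.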

Compound 4, half-maximal inhibitory concentration: > 30000 nM
Compound 4: a limit, no number; the forecaster's own chance of this, stated with the estimate: 65%; the middle value lies on the limit itself.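

Cyclobutyl, a non-aromatic ring of carbon only, ends at the same limit of the assay as the aromatic furan-2-yl and 3,5-dichlorophenyl tails, so an aromatic tail is not required for a compound to sit there, and the limit now dominates this carbonyl carbon: the limit of > 30000 nM in this assay, at which 3 of the 4 values shown sit.

Among the compounds shown here, compound 2 goes against that pattern as the only compound with a number, and exchanging its 3-fluorophenyl for cyclobutyl gives an at least 4.6-fold higher number from compound 2 to compound 4 (0.66 log units; beyond the scatter). The steps from compound 3 to compound 4 and from compound 1 to compound 4 have limits at both ends and cannot be read.

On these data alone, whether the number of compound 2 depends on the fluorine or on the phenyl ring alone stays open, and an unsubstituted phenyl or a 3-chlorophenyl tail on this carbonyl carbon would separate the two. Also open, as far as these compounds go, is whether any non-aromatic tail yields a number at all, for instance a cyclohexyl ring, a longer alkyl chain, or a tail carrying an amine or a carboxylic acid, and how far compound 1, compound 3 and compound 4 differ from one another beyond their shared limit.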